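An Aminoheptyl Chain on the Ring Oxygen

A few compounds are considered here, and "the series" means these few. Any claim that something is new, unique, unknown or untested is made for them only; others in the source may bear on it.

Measured so far in a functional assay on MCF7 cells (Homo sapiens) for antiproliferative activity, read by luminescence, with a stated time of 24 h; on this read-out lower numbers stand for stronger inhibition and higher numbers for weaker inhibition:

Compound 1 `Cc1c(C)c2c(c(C)c1OC(=O)CCCC[C@@H]1SC[C@@H]3NC(=O)N[C@@H]31)CCC(C)(COc1ccc(CC3SC(=O)NC3=O)cc1)O2` gives 15900 nM
Compound 2 `Cc1c(C)c2c(c(C)c1O)CCC(C)(COc1ccc(/C=C3\SC(=O)NC3=O)cc1)O2` gives 29700 nM
Compound 3 `Cc1cc(C)c2c(c1C)OC(C)(COc1ccc(CC3SC(=O)NC3=O)cc1)CC2` gives 20000 nM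

These three values lie within the usual scatter of one another, so compound 2 cannot be ranked against compound 1 or compound 3. Compound 4 `Cc1c(C)c2c(c(C)c1OC(=O)CCCCCCCN)CCC(C)(COc1ccc(/C=C3\SC(=O)NC3=O)cc1)O2` has not yet been measured. It is built from compound 2 by one change ((7-aminoheptyl)carbonyl in place of hydrogen on an oxygen on an aromatic ring), which puts (7-aminoheptyl)carbonyl in place of hydrogen on an oxygen on an aromatic ring.

The closest guide is compound 1, which also carries a large group joined through a carbonyl on that oxygen, although it differs elsewhere too. Compound 1 stays at 15900 nM, and compound 3, which lacks that oxygen, stays at 20000 nM. Three compounds are thin evidence, so no step beyond the scatter is expected in this assay. The expected change is a 1.9-fold lower number from compound 2 to compound 4 (0.27 log units; within the scatter), slightly towards stronger inhibition. The estimated value for compound 4 is 16000 nM, within a range of 6000 nM to 35000 nM.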

Compound 4, half-maximal inhibitory concentration: 3200 nM
Compound 4: middle estimate off by 5.0-fold (0.70 log units), on the high side; measured number below the stated range.
By their numbers in this assay, from the lowest: compound 4; then compounds 1, 3 and 2 (each within the scatter of the next).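

In this assay the change of hydrogen to (7-aminoheptyl)carbonyl on the oxygen on an aromatic ring gives a 9.3-fold lower number from compound 2 to compound 4 (0.97 log units; beyond the scatter) and so moves the number towards stronger inhibition, showing that this oxygen tolerates a large group in this compound. The earlier compounds shown here could not show this: their values lay within the scatter of one another, and no two of them differed in only one place. Nothing measured here gives a reason for this step.

Still open, going by these compounds, is whether the step follows from the amine at the end of the chain or from the chain itself. The same oxygen carrying an unsubstituted alkyl chain of equal length, a shorter aminoalkyl chain or a chain ending in a carboxylic acid would help to separate these two readings.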